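The source may hold more compounds than are shown below. What is called first, only, known or untested is meant among the compounds shown, and "the series" means these compounds.

Measured so far:
compound 1 `CN1[C@@H]2c3[nH]c4ccccc4c3C[C@H]1[C@H](C#N)N1[C@@H](CNC(=O)c3cccc(C(F)(F)F)c3)c3[nH]c4ccccc4c3C[C@@H]21` — 140 nM
compound 2 `CN1[C@@H]2c3[nH]c4ccccc4c3C[C@H]1[C@H](C#N)N1[C@@H](CNC(=O)c3ccc4ccccc4n3)c3[nH]c4ccccc4c3C[C@@H]21` — 150 nM

In a functional assay on HT-29 cells (Homo sapiens) for cytotoxicity, read by MTT assay, with a stated time of 72 h (a lower number here means a stronger inhibitor, a higher number a weaker inhibitor), compound 2 gives 150 nM and compound 1 gives 140 nM; the step of a 1.1-fold higher number from compound 1 to compound 2 (0.03 log units; within the scatter) is within the scatter, so the two compounds cannot be separated on these numbers. Compound 3 `CN1[C@@H]2c3[nH]c4ccccc4c3C[C@H]1[C@H](C#N)N1[C@@H](CNC(=O)c3cc4ccccc4[nH]3)c3[nH]c4ccccc4c3C[C@@H]21` differs from compound 2 by 1H-indol-2-yl in place of quinolin-2-yl on a carbonyl carbon. Among the compounds with values here, the only step measured so far, a 1.1-fold higher number from compound 1 to compound 2 (0.03 log units; within the scatter), also swaps the group on the carbonyl carbon and changed nothing beyond the scatter, so no step beyond the scatter is expected here either: no change at the digits printed from compound 2 to compound 3 (within the scatter). Compound 3 is estimated at 150 nM, within 60 nM to 400 nM.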

Compound 3, half-maximal inhibitory concentration: 1220 nM
Compound 3: middle estimate off by 8.1-fold (0.91 log units), on the low side; measured number outside the range, above it.
By their numbers in this assay, from the lowest: compounds 1 and 2 (each within the scatter of the next); then compound 3.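

In this assay the group on the carbonyl carbon no longer looks indifferent: 1H-indol-2-yl in place of quinolin-2-yl gives a step beyond the scatter (an 8.1-fold higher number from compound 2 to compound 3 (0.91 log units; beyond the scatter)), and 1H-indol-2-yl in place of 3-(trifluoromethyl)phenyl gives another (an 8.7-fold higher number from compound 1 to compound 3 (0.94 log units; beyond the scatter)). Among these three compounds, this position can therefore separate compounds, with compound 3 standing apart. Nothing available bears on the cause of these steps.

Open, on these data alone, is whether a 1-methyl-1H-indol-2-yl group on the same carbonyl carbon would stay near compound 3 or return toward compound 2.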